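The source may hold more compounds than are shown below. What is called first, only, known or untested is meant among the compounds shown, and "the series" means these compounds.

Measured so far in a physicochemical assay for lipophilicity, read by HPLC, measured as octanol-water partition; on this read-out higher numbers stand for higher lipophilicity and lower numbers for lower lipophilicity:
Compound 1 `O=C1O[C@@H](CN2CCC(O)CC2)CN1c1ccc(-n2cc(-c3ccccn3)cn2)c(F)c1` gives 1.63.
Compound 2 `O=C1CCC(=O)N1C[C@H]1CN(c2ccc(-n3cc(-c4ccccn4)cn3)c(F)c2)C(=O)O1` gives 1.58.
Compound 3 `O=C1O[C@@H](CNC(=O)C(F)(F)F)CN1c1ccc(-n2cc(-c3ccccn3)cn2)c(F)c1` gives only a limit of the assay, >= 1.78.

Compound 2 stands lowest of the two numbers that are not limits, with compound 1 nearest: a number 0.05 log units lower from compound 1 to compound 2 (within the scatter). The third value is a limit, as noted.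

Compound 4 `NC(=O)[C@H]1CN(c2ccc(-n3cc(-c4ccccn4)cn3)c(F)c2)C(=O)O1` is the unmeasured compound. Its change from compound 2 is carbamoyl in place of (2,5-dioxopyrrolidin-1-yl)methyl on a saturated ring carbon: the whole (2,5-dioxopyrrolidin-1-yl)methyl group leaves and carbamoyl takes its place on the saturated ring carbon.

Three measured steps are known, and all of them swap one group for another on the saturated chain carbon bound to a saturated ring carbon: a number 0.05 log units lower from compound 1 to compound 2 (within the scatter), a number at least 0.15 log units higher from compound 1 to compound 3 (that floor lies within the scatter) and a number at least 0.20 log units higher from compound 2 to compound 3 (that floor lies within the scatter). The last two reach only the floor set by the limit of >= 1.78 in this assay, at which 1 of the 3 values shown sits. None of these steps removes that chain carbon with its group, as the step to compound 4 does, so they guide only loosely. They show that group swaps at this end of the core moved the read-out little, at most around the scatter.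

Compound 4 is therefore expected to come out somewhat lower than compound 2, with a number 0.28 log units lower from compound 2 to compound 4 (within the scatter), a step near the edge of the scatter. The estimate for compound 4 is 1.3, with a range from 0.9 to 1.7.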

Compound 4, partition coefficient: 1.59
Compound 4: middle estimate off by 0.29 log units, on the low side, within the range that was stated.
By their numbers in this assay, from the lowest: compounds 2, 4 and 1 (each within the scatter of the next). At a limit, above all of these: compound 3.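

In this assay the step to the shorter group gives a number 0.01 log units higher from compound 2 to compound 4 (within the scatter) and the same kind of change gives a number 0.04 log units lower from compound 1 to compound 4 (within the scatter) even though the chain carbon leaves along with the ring of the departing group. The earlier compounds shown here only swapped groups on that chain carbon, whereas here the saturated ring carbon next to the ring oxygen carries the smaller carbamoyl directly, and compounds 1, 2 and 4 remain within the scatter of one another. For compound 3 the value is a limit, >= 1.78 and its step of a number at least 0.19 log units lower from compound 3 to compound 4 (that floor lies within the scatter) can be read only as a floor, so this compound stays outside that agreement, the floor being set by: the limit of >= 1.78 in this assay, at which 1 of the 4 values shown sits.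

From the compounds shown here alone, whether the read-out stays this close with a carboxylic acid or an amine on the same saturated ring carbon remains open. Also open, going by these compounds, is what a longer chain between that ring carbon and the carbamoyl would do, and how far compound 3 really lies from the other three.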